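Propanoyl to methylsulfonyl on the ring amine of compound 3

The source may report more compounds than this note shows. Statements on the series, on what has been measured and on what is new or still open speak of the compounds shown alone.

Three compounds of the series have numbers in a functional assay on CHO-K1 cells for agonist activity at G-protein coupled receptor 6 (Homo sapiens), read by TR-FRET and cAMP accumulation, with a stated time of 20 h; a higher number here means that more compound is needed for the effect, a lower number that less compound is needed. Compound 1 `Cc1cc2nc(NC(C)C)c(N3CCC(Oc4ccc(F)cc4F)CC3)nc2cn1` gives 16000 nM in this assay. Compound 2 `Cc1cc2nc(N3CCC(Oc4ccc(F)cc4F)CC3)c(NC3CC3)nc2cn1` gives 95000 nM in this assay. Compound 3 `CCC(=O)N1C=Cc2nc(N3CCN(Cc4ccc(F)cc4F)CC3)c(NC(C)C)nc2C1` gives 30000 nM in this assay. On these numbers compound 3 stands second highest of the three: its number and that of compound 1 lie within the usual scatter of each other, so no order between them can be read, while compound 2 gives a number beyond the scatter above compound 3.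

Compound 4 `CC(C)Nc1nc2c(nc1N1CCN(Cc3ccc(F)cc3F)CC1)C=CN(S(C)(=O)=O)C2` has not yet been measured. It differs from compound 3 in one place: methylsulfonyl in place of propanoyl on an amine nitrogen in a ring. Going by the values given here, no measured pair shows this change, so nothing in the data tells its size or direction. The expectation is therefore that the number for compound 4 stays close to that of compound 3, with the step from compound 3 to compound 4 in this assay, no change at the digits printed from compound 3 to compound 4 (within the scatter), expected to fall within the scatter. Compound 4 is estimated at 30000 nM in this assay, with a range from 9000 nM to 100000 nM.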

Compound 4, half-maximal effective concentration: 27000 nM
For compound 4 the middle estimate is 1.1-fold (0.05 log units) above the measured one; measured number inside the range.
By their numbers in this assay, from the lowest: compounds 1, 4 and 3 (each within the scatter of the next); then compound 2.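

In this assay, going by these compounds alone, methylsulfonyl in place of propanoyl on the amine nitrogen in a ring gives a 1.1-fold lower number from compound 3 to compound 4 (0.05 log units; within the scatter) and is the first one-place change that can be read. At this position the two groups cannot be told apart in this assay, despite their different atom makeup and the additional hydrogen-bond acceptor counted for methylsulfonyl. Nothing on hand explains why the two groups read alike.

Still open, going by these compounds, is how this position responds to groups of another kind, such as a free ring amine, a carboxylic acid or a longer chain on the same nitrogen. Also open, on these data alone, is whether any replacement here moves the number beyond the scatter; this single step sets no limit on what the position allows.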